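The source may hold more compounds than are shown below. What is called first, only, known or untested is meant among the compounds shown, and "the series" means these compounds.

Compounds measured so far in a functional assay on CCRF-CEM cells (Homo sapiens) for inhibition, read by cell counting, with a stated time of 3 days; a higher number here means a weaker inhibitor, a lower number a stronger inhibitor:
- compound 1, `C=C(Br)C(=O)Nc1cccc(-c2cn3nc(-c4ccc(OCC)cc4)sc3n2)c1`: 1400 nM
- compound 2, `Nc1cccc(-c2cn3nc(-c4ccccc4)sc3n2)c1`: 33000 nM
- compound 3, `CCOc1ccc(-c2nn3cc(-c4cccc(N)c4)nc3s2)cc1`: a limit, > 250000 nM

In this assay compound 1 gives 1400 nM, the lower of the two numbers reported, with compound 2 giving the other number. Compound 3 reaches only a limit of this assay, which is one of the values shown (the limit of > 250000 nM in this assay, at which 1 of the 3 values shown sits). Between compound 1 and compound 3 the step is an at least 170-fold higher number from compound 1 to compound 3 (2.25 log units; beyond the scatter); between compound 2 and compound 3 it is an at least 7.5-fold higher number from compound 2 to compound 3 (0.87 log units; beyond the scatter).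

Compound 4, `C=C(Br)C(=O)Nc1cccc(-c2cn3nc(-c4ccc(CC)cc4)sc3n2)c1`, has not yet been measured. It differs from compound 1 in one place: ethyl in place of ethoxy on an aromatic carbon. Among the measured compounds shown here, no measured step swaps these two groups directly. The step from compound 2 to compound 3, which puts ethoxy in place of hydrogen on an aromatic carbon, was an at least 7.5-fold higher number from compound 2 to compound 3 (0.87 log units; beyond the scatter), so this group does matter to the numbers; ethyl, however, is a far closer replacement for ethoxy than hydrogen is. The expected step in this assay is therefore small, a 1.4-fold higher number from compound 1 to compound 4 (0.13 log units; within the scatter), perhaps within the scatter, with any drift toward a higher number. Compound 4 is estimated at 1900 nM, expected to fall between 600 nM and 6000 nM.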

Compound 4, half-maximal inhibitory concentration: 3400 nM
Compound 4: the middle estimate sits 1.8-fold (0.25 log units) below what was measured; the range from low to high includes it.
By their numbers in this assay, from the lowest: compound 1; then compound 4; then compound 2. At a limit, above all of these: compound 3.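

Among the compounds shown here, this gives the first direct reading of the change from 4-ethoxyphenyl to 4-ethylphenyl, and with the (1-bromoethenyl)carbonyl group on the nitrogen, ethoxy goes with the lower number in this assay: a 2.4-fold higher number from compound 1 to compound 4 (0.39 log units; beyond the scatter). For the compounds shown here, the only earlier step at this aromatic carbon, an at least 7.5-fold higher number from compound 2 to compound 3 (0.87 log units; beyond the scatter), was read on the free amine against a limit, and there ethoxy went with the higher number, so across these two pairs ethoxy does not read the same way on both nitrogen states. Nothing measured here gives a reason for that difference.

From the compounds shown here alone, it remains open how hydrogen at this carbon would read with the (1-bromoethenyl)carbonyl group in place. Also open, going by these compounds, is whether a longer chain such as propoxy, or an amine, would follow ethoxy or ethyl here.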